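Swapping a Hydroxy for an Anilino Group: Expecting Little Change

The source may report more compounds than this note shows. Statements on the series, on what has been measured and on what is new or still open speak of the compounds shown alone.

Compound 1 (`CC(=O)SCCC(CCCCC(=O)O)SC(C)=O`) is the starting point here. In a functional assay on HO8910 cells (Homo sapiens) for inhibition, read by MTT assay, with a stated time of 24 h, tested at 1 ug/mL (on this read-out higher numbers stand for more inhibition of growth at the one concentration tested and lower numbers for less inhibition of growth), compound 1 is reported as "not active" (no number reported), so it offers no single number to measure a change from.

The next compound to be tested is compound 4 (`CC(=O)SCCC(CCCCC(=O)Nc1ccccc1)SC(C)=O`). It keeps the rest of compound 1 and changes in one place, with anilino in place of hydroxy on a carbonyl carbon.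

Among the measured compounds shown here, the only numbers available come from two relatives. In this assay compound 2 (`O=C(CCCCC(S)CCS)Nc1ccccc1Cl`) gives 7.72%, and compound 3 (`COc1ccc(NC(=O)CCCCC(S)CCS)cc1`) gives 1.79%. These two values lie within the usual scatter of each other, the spread seen when such a measurement is simply repeated. Both compounds also carry an aromatic ring, but they differ from compound 4 elsewhere, so neither offers a clean comparison that changes just one place.

For the measured compounds named here, with no such measured step to lean on, the change in this assay is expected to be small, probably no larger than the scatter, and if anything toward slightly more inhibition. That expectation rests on the low readings of compound 2 at 7.72% and compound 3 at 1.79%.

For compound 4 the estimated value is 5%, with an expected range of 0% to 15%.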

Compound 4, percent growth inhibition at one concentration: 10.6%
Compound 4: the middle estimate sits 5.6 percentage points below what was measured; measured number inside the range.
By their numbers in this assay, from the lowest: compounds 3, 2 and 4 (each within the scatter of the next).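

Among the compounds shown here, compound 1 is reported as "not active" (no number reported) while compound 4 gives 10.6%, so no step between them can be read. The compounds shown leave open how far anilino in place of hydroxy on the carbonyl carbon shifts growth inhibition. No supporting data here bear on the reading of compound 4.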